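Switching the indolyl amine for fluorophenyl on compound 3

This account rests on a few compounds, and the source may have more. Where it says the series, first, only, none or still open, it means among the compounds named here.

Compound 1 `O=C(/C=C\Nc1ccc(F)cc1)c1nc(-c2ccc(F)cc2)n2ccccc12` gives 13200 nM in a functional assay on A549 cells (Homo sapiens) for cytotoxicity, read by MTT assay, with a stated time of 48 h; a higher number here means a weaker inhibitor, a lower number a stronger inhibitor.
Compound 2 `COc1ccc(-c2nc(C(=O)/C=C\Nc3ccc4[nH]ccc4c3)c3ccccn23)cc1` gives 4800 nM in this assay.
Compound 3 `O=C(/C=C\Nc1ccc2[nH]ccc2c1)c1nc(-c2ccc(C(F)(F)F)cc2)n2ccccc12` gives 5190 nM in this assay.

Compound 3 stands second highest of the three numbers in this assay, close to compound 2 and well apart from compound 1, whose number is the highest of the three.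

Compound 4 `O=C(/C=C\Nc1ccc(F)cc1)c1nc(-c2ccc(C(F)(F)F)cc2)n2ccccc12` differs from compound 3 in one place: 4-fluorophenyl in place of 1H-indol-5-yl on an amine nitrogen.

Among the compounds with values here, no measured step covers this change alone. Within the data shown here, the one measured step, a 1.1-fold higher number from compound 2 to compound 3 (0.03 log units; within the scatter), concerns the other aryl group on the shared core and lies within the scatter, so that position seems to carry little weight here. Compound 4 carries the same 4-fluorophenyl amine as compound 1. In this assay compound 1 gives 13200 nM. Compound 3 gives 5190 nM. Among the measured compounds shown here, these two compounds differ at both aryl groups, and no measured step separates the two contributions to that gap. Compound 4 is expected to move toward the number of compound 1, an estimated step of a 2.1-fold higher number from compound 3 to compound 4 (0.33 log units; beyond the scatter), beyond the scatter.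

Compound 4 is therefore estimated at 11000 nM, within a range from 5500 nM to 22000 nM.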

Compound 4, half-maximal inhibitory concentration: > 30000 nM
Compound 4: only a limit was reported (the forecaster's own chance of this, stated with the estimate: 10%); at least 2.7-fold (0.43 log units) between middle value and limit.
By their numbers in this assay, from the lowest: compounds 2 and 3 (each within the scatter of the next); then compound 1. At a limit, above all of these: compound 4.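

For compound 4 the reported figure is a limit of the assay, not a number: the limit of > 30000 nM in this assay, at which 1 of the 4 values shown sits. Even so, 4-fluorophenyl in place of 1H-indol-5-yl on the amine nitrogen gives an at least 5.7-fold higher number from compound 3 to compound 4 (0.76 log units; beyond the scatter), the first measured step at this position, and it lies beyond the scatter. The aryl group on the shared core also proves able to shift the number, since trifluoromethyl in place of fluoro gives an at least 2.2-fold higher number from compound 1 to compound 4 (0.35 log units; beyond the scatter), although that is a different change from the one in a 1.1-fold higher number from compound 2 to compound 3 (0.03 log units; within the scatter), which lay within the scatter.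

Going by these compounds, the full size of both new steps stays open, as compound 4 is known only as a limit. A plain phenyl or a 4-methoxyphenyl group on the amine nitrogen would help show which part of the 1H-indol-5-yl group matters in this assay.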